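Methoxy for methyl, carried from one core to another

The compounds below may be only part of what the source reports. "The series", "measured", "known", "first", "only" and "open" are said of these compounds alone.

Measured so far:
compound 1 `Cc1ccc(C2=NN(C3=NC(c4ccccc4)CS3)C(c3ccc4ccccc4c3)C2)cc1`: 2460 nM
compound 2 `COc1ccc(C2=NN(C3=NC(c4ccccc4)CS3)C(c3ccc4ccccc4c3)C2)cc1`: 1860 nM
compound 3 `Cc1ccc(C2=NN(C3=NC(=O)CS3)C(c3cccc4ccccc34)C2)cc1`: 3210 nM

In a functional assay on HeLa cells (Homo sapiens) for inhibition, read by CCK-8 assay, with a stated time of 48 h (on this read-out higher numbers stand for weaker inhibition and lower numbers for stronger inhibition), compound 1 gives 2460 nM and compound 2 gives 1860 nM. The two are related by methoxy in place of methyl on an aromatic carbon, and that change produced a 1.3-fold lower number from compound 1 to compound 2 (0.12 log units; within the scatter). Compound 3 gives 3210 nM in this assay; the difference between its core and the core of compound 1 is not broken down here. Compound 4 `COc1ccc(C2=NN(C3=NC(=O)CS3)C(c3cccc4ccccc34)C2)cc1` is not yet measured. It is related to compound 3 by methoxy in place of methyl on an aromatic carbon, the same change as seen between compound 1 and compound 2, in the same place. Because that change once gave a 1.3-fold lower number from compound 1 to compound 2 (0.12 log units; within the scatter), the step expected here is a 1.3-fold lower number from compound 3 to compound 4 (0.11 log units; within the scatter), a move that stays inside the usual scatter. On that basis compound 4 is estimated at 2500 nM, expected to fall between 1300 nM and 4800 nM.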

Compound 4, half-maximal inhibitory concentration: 2540 nM
Compound 4: the middle estimate sits 1.0-fold (0.01 log units) below what was measured; measured number inside the range.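

In this assay, methoxy in place of methyl gives a 1.3-fold lower number from compound 3 to compound 4 (0.10 log units; within the scatter), and this step matches the one on the other core: the same change on two cores in this assay, a 1.3-fold lower number (0.12 log units; within the scatter) from compound 1 to compound 2 and a 1.3-fold lower number (0.10 log units; within the scatter) from compound 3 to compound 4, 1.0-fold (0.02 log units) apart, within the scatter of two such steps. The change from 4-methylphenyl to 4-methoxyphenyl therefore reads the same on both cores shown, with each step within the scatter. This shows agreement between two small steps only: it does not establish a real effect of the change on either core, nor does it show that a step of clear size would carry over or that the match extends beyond these two pairs.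

Open, on these data alone, is whether an amine, a carboxylic acid or a longer chain in the same place would give a step beyond the scatter. Also open, as far as these compounds go, is how the parts that separate the core of compound 1 from the core of compound 3 each contribute, as those cores differ in more than one place.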